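Chloro to Methyl in a Hydroxy-Bearing Compound

A few compounds are considered here, and "the series" means these few. Any claim that something is new, unique, unknown or untested is made for them only; others in the source may bear on it.

In a functional assay on SGC-7901 cells (Homo sapiens) for antiproliferative activity, read by MTT assay, with a stated time of 72 h (a higher number here means a weaker inhibitor, a lower number a stronger inhibitor), compound 1 `O=C1C=C(N2CCN(c3ccccc3Cl)CC2)C(=O)c2ccccc21` gives 41800 nM, while compound 2 `O=C1C=C(N2CCN(c3ccccc3Cl)CC2)C(=O)c2c(O)cccc21` gives 8200 nM, the lower of the two numbers and so the stronger result. Among the measured compounds shown here, the only measured step, a 5.1-fold lower number from compound 1 to compound 2 (0.71 log units; beyond the scatter), is a modest one beyond the scatter, and the change behind it is hydroxy in place of hydrogen on an aromatic carbon.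

Compound 3 `Cc1ccccc1N1CCN(C2=CC(=O)c3cccc(O)c3C2=O)CC1` keeps that hydroxy and differs from compound 2 in one place: methyl in place of chloro on an aromatic carbon. The measured step bears on this change only indirectly, as it involves a different substitution. For the measured compounds named here, no measured pair shows what this swap does, so the data offer no size for it. No step beyond the scatter is therefore expected in this assay, in either direction, although the uncertainty is wide.

The estimated change is a 1.1-fold higher number from compound 2 to compound 3 (0.04 log units; within the scatter). For compound 3 the expected value is 9000 nM. The estimated range for compound 3 runs from 3500 nM to 23000 nM.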

Compound 3, half-maximal inhibitory concentration: 5300 nM
Estimate against measurement, compound 3: 1.7-fold (0.23 log units) above, and the stated range covers the measured number.
By their numbers in this assay, from the lowest: compounds 3 and 2 (each within the scatter of the next); then compound 1.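

In this assay, the swap of chloro for methyl on an aromatic carbon ortho to a large group gives a 1.5-fold lower number from compound 2 to compound 3 (0.19 log units; within the scatter), so the two compounds cannot be told apart in this read-out. The earlier compounds shown here spoke only to the hydroxy, through a 5.1-fold lower number from compound 1 to compound 2 (0.71 log units; beyond the scatter), and said nothing about this position; this pair adds that, with the hydroxy in place, the 2-chlorophenyl group can give way to 2-methylphenyl with no change that stands out from the scatter. Nothing measured here offers a reason why the two groups read so alike.

The compounds shown leave open whether the same swap would also read alike in a compound without the hydroxy, as both members of this pair carry it. They also leave open how a group of a different kind at this same place, such as methoxy, an amine or a carboxylic acid, would compare with chloro and methyl, so one close pair cannot yet describe this position as a whole.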